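Pyrazolyl carbonyl for cyclohexyl carbonyl: lipophilicity check

This account rests on a few compounds, and the source may have more. Where it says the series, first, only, none or still open, it means among the compounds named here.

Measured so far in a physicochemical assay for lipophilicity, read by HPLC, measured as chromatographic lipophilicity, at pH 7.4; on this read-out higher numbers stand for higher lipophilicity and lower numbers for lower lipophilicity:
- compound 1 `O=C(C1CCN(c2ccncn2)CC1)N1N=CC[C@H]1c1ccccc1` gives 3.2
- compound 2 `O=C(C1CCCCC1)N1CCC(C(=O)N2N=CCC2c2ccccc2)CC1` gives 5.4
- compound 3 `Cc1nnc(N2CCC(C(=O)N3N=CC[C@H]3c3cc(F)cc(F)c3)CC2)o1` gives 3.6

Within this set compound 2 stands highest in this assay. Its nearest neighbour on the numbers is compound 3, a gap that lies beyond the scatter, and the gap to compound 1 is larger still, also beyond the scatter. For the measured compounds named here, none of these three pairs differs in a single place, so no step between measured compounds can be read off; the three numbers are taken as they are.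

Compound 4 `O=C(c1cn[nH]c1)N1CCC(C(=O)N2N=CCC2c2ccccc2)CC1` has not been measured in this assay. It differs from compound 2 in one place: 1H-pyrazol-4-yl in place of cyclohexyl on a carbonyl carbon. A cyclohexyl ring of carbon only gives way to a five-membered aromatic ring with two hetero atoms that brings one hydrogen-bond donor and one hydrogen-bond acceptor. Going by the values given here, with no measured step of this kind available, the expectation rests on the count of what leaves and what enters: a drop in this assay well beyond the scatter is expected, the step from compound 2 to compound 4 being estimated at a number 2.60 log units lower from compound 2 to compound 4 (beyond the scatter). For compound 4 the estimated value in this assay is 2.8, expected to fall between 2.2 and 3.4.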

Compound 4, distribution coefficient: 2.1
Compound 4: middle estimate off by 0.70 log units, on the high side; the measured number lies below the stated range.
By their numbers in this assay, from the lowest: compound 4; then compound 1; then compound 3; then compound 2.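

In this assay, for the compounds shown here, 1H-pyrazol-4-yl in place of cyclohexyl on a carbonyl carbon gives the first step that can be read at a single place, a number 3.30 log units lower from compound 2 to compound 4 (beyond the scatter). The earlier compounds shown here differed from one another in more than one place, so they could not show that this position, on a carbonyl carbon whose other neighbours are amide-type nitrogen in a ring, moves this read-out at all; the step now shows that it does, and by a large amount. Nothing at hand accounts for the size of this step.

The step replaces a six-membered non-aromatic ring of carbon only with a five-membered aromatic ring bearing a hydrogen-bond donor and a hydrogen-bond acceptor, all in a single change, so the compounds shown leave open how much of it goes with each of these differences. From the compounds shown here alone, a phenyl ring or a pyrazole with a methyl group on the ring nitrogen at this same position would separate them, and how either would read in this assay remains open.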